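Amide tail variations: extending the hydroxyalkyl chain

This account rests on a few compounds, and the source may have more. Where it says the series, first, only, none or still open, it means among the compounds named here.

Measured compounds and values in an assay on HEK293 cells for displacement of a labelled ligand from NPC1-like intracellular cholesterol transporter 1 (Homo sapiens); on this read-out lower numbers stand for stronger inhibition and higher numbers for weaker inhibition:
compound 1 `CC(C)(C)c1ccc(C(=O)N2CCC3(CC2)C(=O)N(CC(=O)N2CCCC(C(N)=O)C2)CN3c2ccccc2)cc1`: 16900 nM
compound 2 `CC(C)(C)OC(=O)NCCNC(=O)CN1CN(c2ccccc2)C2(CCN(C(=O)c3ccc(C(C)(C)C)cc3)CC2)C1=O`: 10900 nM
compound 3 `CC(C)(C)c1ccc(C(=O)N2CCC3(CC2)C(=O)N(CC(=O)NCCCCO)CN3c2ccccc2)cc1`: 19200 nM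

All three share the same core and differ only in the group on the carbonyl carbon of the side-chain amide. Compound 3 has the highest of the three numbers, but the distance to compound 1, a 1.1-fold higher number from compound 1 to compound 3 (0.06 log units; within the scatter), and to compound 2, a 1.8-fold higher number from compound 2 to compound 3 (0.25 log units; within the scatter), are both within the scatter, so the three compounds cannot be ordered on these numbers. The remaining step, a 1.6-fold lower number from compound 1 to compound 2 (0.19 log units; within the scatter), is likewise within the scatter.

Compound 4 `CC(C)(C)c1ccc(C(=O)N2CCC3(CC2)C(=O)N(CC(=O)NCCCCCO)CN3c2ccccc2)cc1` is not yet measured. It differs from compound 3 by hydroxymethyl in place of hydroxy on a saturated chain carbon, four bonds along the chain from an amide-type nitrogen; the same difference, cut one bond further out, reads 4-hydroxybutyl to 5-hydroxypentyl.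

For the measured compounds named here, no measured step changes the length of the hydroxyalkyl chain, so the closest guidance is indirect: every variation of this amide tail so far, from a 3-carbamoylpiperidin-1-yl to a (4-hydroxybutyl)amino or a (2-((tert-butoxycarbonyl)amino)ethyl)amino group, stayed within the scatter. A one-carbon extension of the chain is a smaller change than any of those. The expected step, a 1.0-fold lower number from compound 3 to compound 4 (0.00 log units; within the scatter), is therefore none beyond the scatter, in no particular direction. Compound 4 is estimated at 19000 nM, with a range from 9000 nM to 40000 nM.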

Compound 4, half-maximal inhibitory concentration: 9400 nM
Compound 4: the middle estimate sits 2.0-fold (0.31 log units) above what was measured; the range from low to high includes it.
By their numbers in this assay, from the lowest: compounds 4, 2, 1 and 3 (each within the scatter of the next, the first and the last beyond it).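

In this assay, hydroxymethyl in place of hydroxy on a saturated chain carbon, four bonds along the chain from an amide-type nitrogen, gives a 2.0-fold lower number from compound 3 to compound 4 (0.31 log units; beyond the scatter): a modest step, but the first in this amide tail to lie beyond the scatter, showing that the read-out can register a change of 4-hydroxybutyl to 5-hydroxypentyl, even though the larger replacements among compounds 1, 2 and 3 gave no readable difference. The step holds only against compound 3, since a 1.2-fold lower number from compound 2 to compound 4 (0.06 log units; within the scatter) and a 1.8-fold lower number from compound 1 to compound 4 (0.25 log units; within the scatter) leave compound 4 unseparated from the two other tails. Nothing at hand gives a reason for the step.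

On these data alone, a single step does not establish a trend with chain length, so it remains open whether 3-hydroxypropyl, 2-hydroxyethyl or 6-hydroxyhexyl would continue the same direction. Also open, as far as these compounds go, is whether the terminal hydroxy has any part in the step, which a plain pentyl chain, or a terminal amine or carboxylic acid on the same chain, would test.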